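This account rests on a few compounds, and the source may have more. Where it says the series, first, only, none or still open, it means among the compounds named here.

Compound 1 `CCCCCCC/N=C(\NC#N)Nc1cccnc1` was examined in a functional assay on the whole organism (blood, strain Wistar-Okamoto) with Rattus norvegicus as the target, with a stated time of 5 days; a higher number here means that more compound is needed for the effect, a lower number that less compound is needed. In that test compound 1 gives only a limit of the assay, > 50 mg/kg, so no number is known for it. Compound 1 thus stands at the limit of > 50 mg/kg in this assay, at which 1 of the 2 values shown sits. Compound 2 `CCC(CC)/N=C(\NC#N)Nc1cccnc1` gives 20 mg/kg in this assay. Compound 3 `N#CN/C(=N\Cc1ccccc1)Nc1cccnc1` differs from compound 1 by phenyl in place of hexyl on a saturated chain carbon bound to a double-bonded nitrogen. Because compound 1 rests at the limit of > 50 mg/kg in this assay, at which 1 of the 2 values shown sits, the true size of the step to compound 3 cannot be fixed; a move toward a lower dose, beyond the scatter, is expected, an at least 1.6-fold lower number from compound 1 to compound 3 (0.22 log units; that floor lies within the scatter). Compound 3 is estimated to give 30 mg/kg, between 10 mg/kg and 100 mg/kg.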

Compound 3, minimum effective dose: 20 mg/kg
Estimate against measurement, compound 3: 1.5-fold (0.18 log units) above, and the stated range covers the measured number.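

In this assay, phenyl in place of hexyl on a saturated chain carbon bound to a double-bonded nitrogen gives an at least 2.5-fold lower number from compound 1 to compound 3 (0.39 log units; beyond the scatter). An aromatic ring at this place is therefore compatible with a measurable effective dose, which the open-chain compounds could not show. Going by these compounds, the true size of the step stays unknown because compound 1 rests at a limit and not at a number: the limit of > 50 mg/kg in this assay, at which 1 of the 3 values shown sits.

On these data alone, it remains open how a saturated cyclohexyl ring would compare at this place, which would help separate having a ring from having an aromatic one. As far as these compounds go, the effect of a methoxy group or chlorine atom on the phenyl ring is also open.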